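A few compounds are considered here, and "the series" means these few. Any claim that something is new, unique, unknown or untested is made for them only; others in the source may bear on it.

Three compounds built on one shared core have been run through a functional assay on HL-60 cells (Homo sapiens) for cytotoxicity, read by MTT assay, with a stated time of 4 days; on this read-out higher numbers stand for weaker inhibition and lower numbers for stronger inhibition. Compound 1 `C=C1C(=O)[C@]23C[C@@]1(O)CC[C@H]2c1ccc(OS(=O)(=O)c2ccc(C)cc2)c(C)c1[C@@H]3Cn1cc(-c2ccc(F)cc2)nn1` gives 1290 nM. Compound 2 `C=C1C(=O)[C@]23C[C@@]1(O)CC[C@H]2c1ccc(O)c(C)c1[C@@H]3Cn1cc(-c2ccccn2)nn1` gives 1970 nM. Compound 3 `C=C1C(=O)[C@]23C[C@@]1(O)CC[C@H]2c1ccc(OS(=O)(=O)c2ccc(C)cc2)c(C)c1[C@@H]3Cn1cc(-c2ccc(OC)cc2)nn1` gives 1020 nM, the lowest of the three numbers, yet its nearest neighbour, compound 1, and its furthest, compound 2, both sit within the scatter of it, so no order among the three can be claimed. Among the compounds with values here, the only step between two close relatives, a 1.3-fold lower number from compound 1 to compound 3 (0.10 log units; within the scatter), also falls within the scatter.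

Compound 4 `C=C1C(=O)[C@]23C[C@@]1(O)CC[C@H]2c1ccc(OS(=O)(=O)c2ccc(C)cc2)c(C)c1[C@@H]3Cn1cc(-c2ccccn2)nn1` has not yet been measured. It differs from compound 3 in one place: pyridin-2-yl in place of 4-methoxyphenyl on an aromatic carbon. Within the data shown here, no measured step covers this exchange directly. Compound 2 carries the same pyridin-2-yl group but on a core that differs elsewhere, so compound 2 with its 1970 nM speaks to compound 4 only loosely. Among the measured compounds shown here, all numbers so far lie in a narrow band, and the one measured exchange of aromatic rings at this position moved little. Compound 4 is therefore expected to show a step of a 1.4-fold higher number from compound 3 to compound 4 (0.14 log units; within the scatter), nothing beyond the scatter. Compound 4 is estimated at 1400 nM, with a range from 700 nM to 2800 nM.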

Compound 4, half-maximal inhibitory concentration: 1810 nM
Estimate against measurement, compound 4: 1.3-fold (0.11 log units) below; the measured number falls inside the stated range.
By their numbers in this assay, from the lowest: compounds 3, 1, 4 and 2 (each within the scatter of the next).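

In this assay the aromatic carbon of the five-membered aromatic ring with 3 nitrogen has now carried a ring with a hetero atom as well as rings of carbon only, and the read-out stays within the scatter for both exchanges: pyridin-2-yl in place of 4-methoxyphenyl (a 1.8-fold higher number from compound 3 to compound 4 (0.25 log units; within the scatter)) and pyridin-2-yl in place of 4-fluorophenyl (a 1.4-fold higher number from compound 1 to compound 4 (0.15 log units; within the scatter)). Within the data shown here, the new compound also gives the first direct reading of the group on the oxygen with everything else held the same, since (4-methylphenyl)sulfonyl in place of hydrogen leaves the number within the scatter as well (a 1.1-fold lower number from compound 2 to compound 4 (0.04 log units; within the scatter)). No measurement shown here offers an explanation for these results.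

Going by these compounds, what an amine, a carboxylic acid or a longer carbon chain would do in place of these aromatic rings remains open, and so does the effect of pyridin-3-yl. On these data alone, the exchange on the oxygen is read here only with pyridin-2-yl on the shared core, so its size with 4-fluorophenyl or 4-methoxyphenyl also remains open.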